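The compounds below may be only part of what the source reports. "The series", "measured", "known", "first", "only" and "open" are said of these compounds alone.

Measured in a functional assay on HeLa cells (Homo sapiens) for inhibition, read by MTT assay, with a stated time of 72 h; on this read-out lower numbers stand for stronger inhibition and higher numbers for weaker inhibition:
- Compound 1 `COc1cccc(NC(=O)Nc2ccc(Oc3ncnc4[nH]ncc34)cc2)c1`: > 10000 nM
- Compound 2 `COc1cccc(NC(=O)Nc2ccc(Oc3ncnc4c3cnn4C)cc2)c1`: > 10000 nM
- Compound 3 `O=C(Nc1ccc(C(F)(F)F)cc1)Nc1cccc(Oc2ncnc3[nH]ncc23)c1`: > 10000 nM

In this assay, compound 1 gives > 10000 nM, which is a limit of the assay and not a number. The same is true of the other two compounds, so the data so far come down to one line: the limit of > 10000 nM in this assay, at which 3 of the 3 values shown sit.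

Compound 4 `O=C(Nc1ccc(Oc2ncnc3[nH]ncc23)cc1)NC1CCCCC1` keeps the core of compound 1 but carries cyclohexyl in place of 3-methoxyphenyl on an amide-type nitrogen.

Among the compounds with values here, only one measured step exists, and it is made elsewhere in the molecule, with methyl in place of hydrogen on an aromatic nitrogen: a step that the two limits leave unreadable from compound 1 to compound 2. It therefore offers no size to carry over to this change. With no readable step to build on, no shift beyond the usual scatter is expected in this assay, and a reading at the same limit seems most likely.

The expected change is a step that the limit leaves unreadable from compound 1 to compound 4. For compound 4 the estimated value is 15000 nM, with an expected range of 6000 nM to 40000 nM.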

Compound 4, half-maximal inhibitory concentration: > 10000 nM
Compound 4 was reported as a limit (the forecaster's own chance of this, stated with the estimate: 85%); the middle value lies beyond the limit too.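

In this assay, within the data shown here, compound 1 and compound 4 both read as limits and not as numbers, so no step between them can be read. The compounds shown leave open which change, if any, would give a measurable value, because all remain at one reading: the limit of > 10000 nM in this assay, at which 4 of the 4 values shown sit.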